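A few compounds are considered here, and "the series" means these few. Any claim that something is new, unique, unknown or untested is made for them only; others in the source may bear on it.

Compounds measured:
compound 1 `Cc1cccc(COc2ccc(C3=NN(CCC#N)C(=O)CO3)cc2)c1` in an assay for inhibition of Amine oxidase [flavin-containing] A (Rattus norvegicus); on this read-out lower numbers stand for stronger inhibition and higher numbers for weaker inhibition: 40000 nM
compound 2 `N#CCCN1N=C(c2ccc(OCc3cccc(Cl)c3)cc2)OCC1=O` in this assay: 13000 nM

Compound 2 gives the lowest of the two numbers; its nearest neighbour is compound 1, and the gap is a 3.1-fold lower number from compound 1 to compound 2 (0.49 log units; beyond the scatter). Compound 3 `N#CCCN1N=C(c2ccc(OCc3ccc(Cl)cc3)cc2)OCC1=O` differs from compound 2 by 4-chlorophenyl in place of 3-chlorophenyl on a saturated chain carbon bound to an oxygen on an aromatic ring. For the measured compounds named here, the single measured step, a 3.1-fold lower number from compound 1 to compound 2 (0.49 log units; beyond the scatter), exchanges one group for another at the same place and says nothing about shifting the chlorine on the ring; no measured step bears on this change. Compound 3 is therefore expected to show no step beyond the scatter, no change at the digits printed from compound 2 to compound 3 (within the scatter). The estimate for compound 3 is 13000 nM, with a range of 4500 nM to 38000 nM.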

Compound 3, half-maximal inhibitory concentration: 3400 nM
Estimate against measurement, compound 3: 3.8-fold (0.58 log units) above; the measured number lies below the stated range.
By their numbers in this assay, from the lowest: compound 3; then compound 2; then compound 1.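

In this assay, the place of the chlorine on the ring matters: with the same atoms joined differently, 4-chlorophenyl in place of 3-chlorophenyl gives a further gain (a 3.8-fold lower number from compound 2 to compound 3 (0.58 log units; beyond the scatter)). Set against the 3-methylphenyl group, the 4-chlorophenyl group gives the largest step in the series so far (a 12-fold lower number from compound 1 to compound 3 (1.07 log units; beyond the scatter)). No measurement at hand accounts for the preference for 4-chlorophenyl. Still open, from the compounds shown here alone, is whether 4-methylphenyl would follow 4-chlorophenyl, which would separate the identity of the group from its place on the ring. Also open, going by these compounds, is how 4-methoxyphenyl or 4-aminophenyl would read at this place.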